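The compounds below may be only part of what the source reports. "The series", "measured", "known", "first", "only" and "open" are said of these compounds alone.

Compound 1 `Cn1cc(-c2n[nH]c3ccc(NC4CCNC4)cc23)cn1`: "not determined" (no result reported) in an assay on HEK293 cells for displacement of a labelled ligand from tyrosine-protein kinase receptor UFO (Homo sapiens), read by NanoBRET, with a stated time of 2 h; a higher number here means a weaker inhibitor, a lower number a stronger inhibitor.
Compound 2 `Cn1cc(-c2n[nH]c3ccc(N[C@H]4CCNC4)cc23)cn1`: > 50000 nM, a limit of this assay and not a number.
Compound 3 `COc1ccc(-n2cc(-c3n[nH]c4cc(Cl)c(N[C@@H]5CCNC5)cc34)cn2)cc1`: 374 nM.

Within the data shown here, compound 3 therefore gives the only number in this assay; one further value sits at a limit (the limit of > 50000 nM in this assay, at which 1 of the 3 values shown sits), and the third entry carries no result at all. Compound 4 `N#Cc1ccccc1-n1cc(-c2n[nH]c3cc(Cl)c(N[C@@H]4CCNC4)cc23)cn1` is still to be measured, and differs from compound 3 by 2-cyanophenyl in place of 4-methoxyphenyl on an aromatic nitrogen. Among the measured compounds shown here, no measured pair shows a change of this kind, so nothing here fixes its size or direction; the expected step of a 1.5-fold higher number from compound 3 to compound 4 (0.17 log units; within the scatter) is small, within or only just beyond the usual scatter. Compound 4 is accordingly estimated at 550 nM, with a range from 150 nM to 2000 nM.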

Compound 4, half-maximal inhibitory concentration: 3540 nM
Compound 4: the middle estimate sits 6.4-fold (0.81 log units) below what was measured, and the stated range ends below it.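

Among these compounds, this is the first measured step at the aromatic nitrogen of the five-membered ring: in this assay, 2-cyanophenyl in place of 4-methoxyphenyl gives a 9.5-fold higher number from compound 3 to compound 4 (0.98 log units; beyond the scatter) and lies beyond the scatter. The group on this nitrogen therefore matters to the reading, even though the two groups match in heavy atoms and hydrogen-bond acceptors. Nothing available bears on the cause of this step.

Still open, from the compounds shown here alone, is whether the step follows the nitrile, the lost methoxy or the place of each group on the phenyl ring. Plain phenyl, 4-cyanophenyl and 2-methoxyphenyl on the same nitrogen remain outside the compounds shown.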